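The compounds below may be only part of what the source reports. "The series", "measured", "known", "first", "only" and "open" are said of these compounds alone.

Measured compounds:
- Compound 1 `O=C(O)C[C@@](O)(C[C@H](O)CCCCCn1ccc2cc(Cl)ccc21)C(=O)O`: in an assay on isolated protein for inhibition of ATP-citrate synthase (Homo sapiens) (a lower number here means a stronger inhibitor, a higher number a weaker inhibitor), compound 1 gives 3500 nM.
- Compound 2 `O=C(O)C[C@@](O)(C[C@H](O)CCCCCn1cc(Cc2ccccc2)c2cc(Cl)ccc21)C(=O)O`: in this assay compound 2 gives 2900 nM.

Within the data shown here, of these two numbers, compound 1 is not separated from compound 2, since the single measured step, a 1.2-fold lower number from compound 1 to compound 2 (0.08 log units; within the scatter), lies within the scatter. Compound 3 `O=C(O)C[C@@](O)(C[C@H](O)CCCCCn1c(-c2ccccc2)cc2cc(Cl)ccc21)C(=O)O` differs from compound 1 by phenyl in place of hydrogen on an aromatic carbon. The step that bears on this, a 1.2-fold lower number from compound 1 to compound 2 (0.08 log units; within the scatter), also added an aromatic group to the same core and left the number essentially unchanged, so no step beyond the scatter is expected in this assay. The estimate for compound 3 is 3000 nM, ranging from 1200 nM to 8000 nM, which means an expected 1.2-fold lower number from compound 1 to compound 3 (0.07 log units; within the scatter).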

Compound 3, inhibition constant: 370 nM
Compound 3: middle estimate off by 8.1-fold (0.91 log units), on the high side; measured number below the stated range.
By their numbers in this assay, from the lowest: compound 3; then compounds 2 and 1 (each within the scatter of the next).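

Placing phenyl on the aromatic carbon next to the ring nitrogen gives a 9.5-fold lower number from compound 1 to compound 3 (0.98 log units; beyond the scatter) in this assay, so this position can respond to an added aromatic ring. The earlier benzyl change gave a 1.2-fold lower number from compound 1 to compound 2 (0.08 log units; within the scatter) at another aromatic carbon, so adding an aromatic group does not by itself shift the number. Nothing available here accounts for the difference between these two steps.

Still open, going by these compounds, is whether methyl, or a phenyl ring carrying an amine or a carboxylic acid, would give a similar step at this position.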